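A Trifluoromethyl Swap on the Urea Aryl Ring

The compounds below may be only part of what the source reports. "The series", "measured", "known", "first", "only" and "open" are said of these compounds alone.

Three ureas built on one shared core have been measured in an ADME assay on the whole organism with Oryza sativa as the target, tested at 0.1 uM; a lower number here means a stronger effect, a higher number a weaker effect of the compound at the concentration tested. Compound 3 `C[C@@H](NC(=O)Nc1cccc(F)c1F)c1ccccc1` gives 100%; the nearest number is that of compound 2 `C[C@@H](NC(=O)Nc1ccccc1F)c1ccccc1`, which gives 97%, within the scatter, and the furthest that of compound 1 `C[C@@H](NC(=O)Nc1cccc(C(F)(F)F)c1)c1ccccc1`, which gives 82%, beyond the scatter. Among the compounds with values here, the only single-place step known, a number 3 percentage points higher from compound 2 to compound 3 (within the scatter), lies within the scatter. Compound 4 `C[C@@H](NC(=O)Nc1cccc(C(F)(F)F)c1F)c1ccccc1` differs from compound 3 by trifluoromethyl in place of fluoro on an aromatic carbon. Within the data shown here, no measured step covers this change; compound 1, the only other trifluoromethyl compound, merely shows a lower number than compound 2. A modest drop in this assay is therefore expected, a number 10 percentage points lower from compound 3 to compound 4 (within the scatter). Compound 4 is estimated at 90%, between 78% and 100%.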

Compound 4, a percentage reported as activity, at one concentration (the size of the read-out at that concentration, not a potency): 99%
Estimate against measurement, compound 4: 9 percentage points below, within the range that was stated.
By their numbers in this assay, from the lowest: compound 1; then compounds 2, 4 and 3 (each within the scatter of the next).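

In this assay, trifluoromethyl on this aromatic carbon, ortho to a fluoro group, is tolerated as a replacement for fluoro, with a number 1 percentage points lower from compound 3 to compound 4 (within the scatter), and for hydrogen, with a number 2 percentage points higher from compound 2 to compound 4 (within the scatter). The lower number of compound 1 does not persist once fluoro replaces hydrogen on its ring, with a number 17 percentage points higher from compound 1 to compound 4 (beyond the scatter). The size of this fluoro step cannot be separated from that of the same change on the other core: the same change on two cores in this assay, a number 3 percentage points higher (within the scatter) from compound 2 to compound 3 and a number 17 percentage points higher (beyond the scatter) from compound 1 to compound 4, 14 percentage points apart, within the scatter of two such steps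

The compounds shown leave open whether an amine or a carboxylic acid on this aromatic carbon would shift the number in this assay.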